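This account rests on a few compounds, and the source may have more. Where it says the series, first, only, none or still open, it means among the compounds named here.

Compound 3 `CN(C)c1ccc2c(O)c(C(=O)O)cnc2c1` holds the lowest of the three numbers in an assay on isolated protein with malate dehydrogenase, mitochondrial (Sus scrofa) as the target; a lower number here means a stronger inhibitor, a higher number a weaker inhibitor: compound 3 gives 479000 nM, while compound 2 `O=C(O)c1ccc2c(O)c(C(=O)O)cnc2c1` gives 1070000 nM and compound 1 `O=C(O)c1cnc2cc(S(=O)(=O)O)ccc2c1O` gives 2140000 nM. The two steps leading down to it, a 4.5-fold lower number from compound 1 to compound 3 (0.65 log units; beyond the scatter) and a 2.2-fold lower number from compound 2 to compound 3 (0.35 log units; beyond the scatter), are both modest, whereas a 2.0-fold lower number from compound 1 to compound 2 (0.30 log units; within the scatter) lies within the scatter; exchanging the group on that aromatic carbon has so far moved the number only a little.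

Compound 4 `O=C(O)c1cnc2cc(O)ccc2c1O` has not yet been measured in this assay. Its change from compound 3 is hydroxy in place of dimethylamino on an aromatic carbon. Among the measured compounds shown here, no measured step swaps dimethylamino for hydroxy, so the only guidance is indirect: the steps from the sulfo and carboxy compounds to compound 3 show modest movement, and a further exchange at the same carbon is unlikely to do more. Hydroxy resembles neither the groups left behind nor dimethylamino closely, so the expectation is for no change beyond the scatter or a small rise back toward compound 2. The expected step for compound 4 is a 1.4-fold higher number from compound 3 to compound 4 (0.13 log units; within the scatter). Compound 4 is estimated to give 650000 nM in this assay, within a range from 200000 nM to 2100000 nM.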

Compound 4, half-maximal inhibitory concentration: 490000 nM
Beside the measured number, compound 4's estimate is 1.3-fold (0.12 log units) above it, within the range that was stated.
By their numbers in this assay, from the lowest: compounds 3 and 4 (each within the scatter of the next); then compounds 2 and 1 (each within the scatter of the next).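

At this aromatic carbon, hydroxy and dimethylamino cannot be told apart in this assay (a 1.0-fold higher number from compound 3 to compound 4 (0.01 log units; within the scatter)), even though the exchange removes 3 heavy atoms and brings in 1 hydrogen-bond donor. Among the compounds shown here, neither the size of the group nor the presence of that donor therefore separates these two compounds, a contrast that no earlier pair could test. Hydroxy also repeats the modest separation seen with dimethylamino (a 2.2-fold lower number from compound 2 to compound 4 (0.34 log units; beyond the scatter) and a 4.4-fold lower number from compound 1 to compound 4 (0.64 log units; beyond the scatter)), so the four compounds now form two groups, with compound 3 and compound 4 together and compound 1 and compound 2 together, and none of the four goes against this split.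

On these data alone, whether methoxy, a primary amine or plain hydrogen on this carbon would join compound 3 and compound 4 remains open, as does whether a longer chain, such as ethoxy or a larger dialkylamine, would leave the number unchanged. Nothing available accounts for the split between hydroxy and dimethylamino on one side and carboxy and sulfo on the other.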